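One Methyl Less: Expecting Little Change in Inhibition

This account rests on a few compounds, and the source may have more. Where it says the series, first, only, none or still open, it means among the compounds named here.

compound 1, `COc1ccc(/C=C/C(=O)c2ccc(O)cc2)cc1Br`: 6.6%
compound 2, `COc1ccc(C(=O)/C=C/c2ccc(OC)c(Br)c2)c(O)c1`: 3.8%

Of the compounds shown here, two have been tested in an assay on isolated protein for inhibition of DNA topoisomerase 1 (Homo sapiens), tested at 20 uM; a higher number here means a stronger effect of the compound at the concentration tested, a lower number a weaker effect. Compound 1 gives 6.6% there, and compound 2 gives 3.8%. These two numbers lie within the usual scatter of each other, so compound 2 stands beside compound 1 rather than apart from it: both show only a small effect at the concentration tested, and neither can be called the weaker or the stronger of the pair. For the measured compounds named here, no pair of measured compounds differs in just one place, so no measured step is available as a guide.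

Compound 3, `COc1ccc(/C=C/C(=O)c2ccc(O)cc2O)cc1Br`, is not yet measured. It differs from compound 2 in one place:

hydrogen in place of methyl on an oxygen on an aromatic ring

Because the two measured values, 6.6% for compound 1 and 3.8% for compound 2, are both small and within scatter of each other, the step from compound 2 to compound 3 is expected to be none beyond the scatter, a number 1.2 percentage points higher from compound 2 to compound 3 (within the scatter). For compound 3 the estimated value in this assay is 5%, with a range from -5% to 15%.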

Compound 3, a percentage reported as inhibition, at one concentration (the size of the read-out at that concentration, not a potency): 8.2%
For compound 3 the middle estimate is 3.2 percentage points below the measured one; low and high end bracket the measured number.
By their numbers in this assay, from the lowest: compounds 2, 1 and 3 (each within the scatter of the next).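

Read in this assay, the swap of methoxy to hydroxy, on an oxygen on an aromatic ring, gives a number 4.4 percentage points higher from compound 2 to compound 3 (within the scatter) and so does not separate the two compounds: at this position, the methyl on the oxygen can go without any change that rises above the noise of the measurement. The other new comparison, hydroxy in place of hydrogen on an aromatic carbon, gives a number 1.6 percentage points higher from compound 1 to compound 3 (within the scatter), so adding this hydroxy to the core of compound 1 does not set the two compounds apart either. No other information on these compounds bears on these readings.

All three compounds differ only by amounts within the scatter, so the shown data do not reveal whether this position can influence the inhibition at all. From the compounds shown here alone, it remains open whether a longer chain on that oxygen, such as an ethyl or a propyl group, or a different group on the aromatic carbon, such as an amine or a carboxylic acid, would produce a step beyond the scatter.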